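From a five-membered ring to a single fluorine

A few compounds are considered here, and "the series" means these few. Any claim that something is new, unique, unknown or untested is made for them only; others in the source may bear on it.

Compound 1 `CC1C(=O)N(c2ccccc2C(=O)OCC2CCCN(CCCc3ccccc3)C2)C(=O)C1C` gives 6000 nM in a functional assay with Neuronal acetylcholine receptor; alpha3/beta4 (Homo sapiens) as the target; on this read-out lower numbers stand for stronger inhibition and higher numbers for weaker inhibition.
Compound 2 `CCCCC1CC(=O)N(c2ccccc2C(=O)OCC2CCCN(CCCc3ccccc3)C2)C1=O` gives 1500 nM in this assay.
Compound 3 `C=CCC1CC(=O)N(c2ccccc2C(=O)OCC2CCCN(CCCc3ccccc3)C2)C1=O` gives 1700 nM in this assay.

Compound 3 stands second highest of the three numbers. Its nearest neighbour is compound 2, and those two values lie within the scatter of each other (a 1.1-fold higher number from compound 2 to compound 3 (0.05 log units; within the scatter)), while compound 1 is furthest away (a 3.5-fold lower number from compound 1 to compound 3 (0.55 log units; beyond the scatter)). Compound 4 `O=C(OCC1CCCN(CCCc2ccccc2)C1)c1ccccc1F` differs from compound 3 by one fluorine atom in place of a group of 10 heavy atoms (7 carbon, 1 nitrogen, 2 oxygen; one five-membered non-aromatic ring with 1 hetero atom), on an aromatic carbon. Among the compounds with values here, none of the measured steps removes that ring group as a whole. The steps of a 4.0-fold lower number from compound 1 to compound 2 (0.60 log units; beyond the scatter) and a 3.5-fold lower number from compound 1 to compound 3 (0.55 log units; beyond the scatter) both change what sits on the ring and both moved the number modestly, and a 1.1-fold higher number from compound 2 to compound 3 (0.05 log units; within the scatter) shows that swapping the chain on the ring changed nothing beyond the scatter. These steps therefore give only a loose reference: a change that takes away the whole group is of a different kind, and the data do not tell its direction. Compound 4 is therefore expected to give 5000 nM in this assay, with a range from 1000 nM to 25000 nM. This estimate means an expected step of a 2.9-fold higher number from compound 3 to compound 4 (0.47 log units; beyond the scatter), a range wide enough that a shift beyond the scatter in either direction cannot be excluded.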

Compound 4, half-maximal inhibitory concentration: 5200 nM
Compound 4: the middle estimate sits 1.0-fold (0.02 log units) below what was measured; measured number inside the range.
By their numbers in this assay, from the lowest: compounds 2 and 3 (each within the scatter of the next); then compounds 4 and 1 (each within the scatter of the next).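

Taking the whole ring group off this aromatic carbon and leaving one fluorine now gives the change a direction in this assay, at least against the two rings carrying a single chain: the steps are a 3.1-fold higher number from compound 3 to compound 4 (0.49 log units; beyond the scatter) and a 3.5-fold higher number from compound 2 to compound 4 (0.54 log units; beyond the scatter), both beyond the scatter and of similar size. Compound 1 goes against this pattern, since its ring with two methyl groups gives a 1.2-fold lower number from compound 1 to compound 4 (0.06 log units; within the scatter), so this ring group and the fluorine cannot be told apart there. At this position, then, the five-membered ring alone shows no advantage over a single fluorine, and the lower numbers appear only in compound 2 and compound 3, where the ring carries a longer chain. Nothing shown here explains why the number moves with this change.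

From the compounds shown here alone, it remains open whether another small group on this aromatic carbon, such as a chlorine, a methoxy or an amine, would fall with compound 4 or with compound 2. Going by these compounds, it is also open whether a still longer chain on the five-membered ring, or a carboxylic acid at its end, would move the number further.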